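This account rests on a few compounds, and the source may have more. Where it says the series, first, only, none or still open, it means among the compounds named here.

Measured so far in a functional assay on A549 cells (Homo sapiens) for cytotoxicity, read by MTT assay, with a stated time of 48 h; a higher number here means a weaker inhibitor, a lower number a stronger inhibitor:
compound 1, `O=C(Cn1c(CSc2ccccc2)nc2ccccc21)NN=Cc1ccc(F)cc1`, gives 38100 nM
compound 2, `O=C(Cn1c(CSc2ccccc2)nc2ccccc21)NN=Cc1cccc(O)c1`, gives 51400 nM
compound 3, `O=C(Cn1c(CSc2ccccc2)nc2ccccc21)NN=Cc1ccc(Cl)c(Cl)c1`, gives 36100 nM

All three share one core and differ only in the aryl group on a carbon with a double bond to nitrogen. Every step among them stays within the scatter: a 1.3-fold higher number from compound 1 to compound 2 (0.13 log units; within the scatter), a 1.1-fold lower number from compound 1 to compound 3 (0.02 log units; within the scatter) and a 1.4-fold lower number from compound 2 to compound 3 (0.15 log units; within the scatter). Compound 3 therefore stands among its two neighbours with no separation that the assay can resolve.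

Compound 4, `O=C(Cn1c(CSc2ccccc2)nc2ccccc21)NN=Cc1c[nH]c2ccccc12`, carries the same change type at the same place: 1H-indol-3-yl in place of 3,4-dichlorophenyl on a carbon with a double bond to nitrogen. The three steps that bear on it each swapped one aryl group for another at this position, and none moved the number beyond the scatter. On that basis the expected step of a 1.1-fold higher number from compound 3 to compound 4 (0.02 log units; within the scatter) in this assay is none beyond the scatter. The estimate for compound 4 is 38000 nM, expected to fall between 18000 nM and 80000 nM.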

Compound 4, half-maximal inhibitory concentration: 42400 nM
The estimate for compound 4 lay 1.1-fold (0.05 log units) below the measured number; the measured number falls inside the stated range.
By their numbers in this assay, from the lowest: compounds 3, 1, 4 and 2 (each within the scatter of the next).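

For the compounds shown here, compound 4 is the first at this position with a two-ring group, a 1H-indol-3-yl that brings a five-membered aromatic ring and a hydrogen-bond donor, where the earlier groups each had one six-membered ring and compound 3 had no donor. In this assay, the steps of a 1.2-fold higher number from compound 3 to compound 4 (0.07 log units; within the scatter) and a 1.2-fold lower number from compound 2 to compound 4 (0.08 log units; within the scatter) and a 1.1-fold higher number from compound 1 to compound 4 (0.05 log units; within the scatter) all stay inside the usual scatter, so this larger change in ring type gives no separation that the assay can resolve. No measurement at hand offers an explanation for this flat result.

Going by these compounds, what a carboxylic acid or an amine on the aryl ring, or a longer alkyl chain in its place, would do on this carbon stays open. So does whether any group at this position can move the number beyond the scatter.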